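Mirror-image pair in the fluoro-substituted pyrrolidine series

The compounds below may be only part of what the source reports. "The series", "measured", "known", "first", "only" and "open" are said of these compounds alone.

Measured so far:
compound 1 `OC[C@]1(c2ccccc2)NC[C@H](O)[C@H]1O` — 190 nM
compound 2 `OC[C@]1(c2cccc(F)c2)NC[C@H](O)[C@H]1O` — 43000 nM

Compound 1 `OC[C@]1(c2ccccc2)NC[C@H](O)[C@H]1O` carries an unsubstituted phenyl on the shared core and in an assay on isolated protein for inhibition of lysosomal alpha-glucosidase (Rattus norvegicus), read by colorimetric assay (a lower number here means a stronger inhibitor, a higher number a weaker inhibitor), compound 1 gives 190 nM. Compound 2 `OC[C@]1(c2cccc(F)c2)NC[C@H](O)[C@H]1O` differs by fluoro in place of hydrogen on an aromatic carbon, and in this assay compound 2 gives 43000 nM. That single change was a 230-fold higher number from compound 1 to compound 2 (2.35 log units; beyond the scatter). Compound 2 therefore stands with the highest number of the two measured, its nearest neighbour being compound 1 at a far lower number.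

Compound 3 `OC[C@@]1(c2cccc(F)c2)NC[C@@H](O)[C@@H]1O` is the next step: the two compounds have the same atoms and bonds and differ only in configuration as drawn: 3 of 3 stereo elements differ (all stereocentres are inverted: mirror images); a stereocentre at a saturated ring carbon is drawn S in compound 2 and R in compound 3; a stereocentre at a saturated ring carbon is drawn S in compound 2 and R in compound 3; a stereocentre at a saturated ring carbon is drawn S in compound 2 and R in compound 3. Among the measured compounds shown here, no measured step concerns a change of configuration, so neither the step from compound 1 to compound 2 nor anything else here tells how large an effect inversion of all three centres has in this assay, or in which direction. For the measured compounds named here, the only anchor is the number for compound 2 itself. Compound 3 is therefore estimated near 60000 nM, with a wide range from 5000 nM to 400000 nM, meaning an expected step of a 1.4-fold higher number from compound 2 to compound 3 (0.14 log units; within the scatter) that may not rise beyond the scatter.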

Compound 3, half-maximal inhibitory concentration: 216000 nM
Compound 3: the middle estimate sits 3.6-fold (0.56 log units) below what was measured, and the stated range covers the measured number.
By their numbers in this assay, from the lowest: compound 1; then compound 2; then compound 3.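

Inverting all three stereocentres of compound 2, with nothing entering or leaving, gives a 5.0-fold higher number from compound 2 to compound 3 (0.70 log units; beyond the scatter) in this assay, so configuration alone shifts the number by more than the scatter in this fluoro-substituted pair. Compound 2 therefore does not mark the top of the series: the order now runs from compound 1 through compound 2 to compound 3, and the mirror image is the weaker inhibitor of this pair. The step can be assigned to configuration rather than to any change of group because nothing else separates the pair: the fact that compounds 2 and 3 differ only in the configuration as drawn

Open, on these data alone, is how much of this step belongs to each of the three centres, and whether inversion moves the number in the same direction and by a similar size when the phenyl is unsubstituted, as in compound 1, where the starting number is far lower. Also open, as far as these compounds go, is whether the step holds with another group in place of the fluoro, such as a chloro, a methoxy or an amine.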